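The source may report more compounds than this note shows. Statements on the series, on what has been measured and on what is new or still open speak of the compounds shown alone.

Compound 1, `Nc1ncnn2c([C@@H]3O[C@H](CO)C[C@H]3O)cc(-c3ccc(Cl)cc3)c12`, is tolerated in an ADME assay on cells (Macrophage, Mus musculus) for cytotoxicity (a lower number here means that less compound is tolerated, a higher number that more compound is tolerated), at 24000 nM. Compound 2, `Nc1ncnn2c([C@@H]3O[C@H](CO)[C@@H](O)[C@H]3O)cc(-c3ccc(Cl)c(F)c3)c12`, differs from it in more than one place. In this assay compound 2 returns only a limit, > 64000 nM. That limit is the limit of > 64000 nM in this assay, at which 1 of the 2 values shown sits, so the position of compound 2 is known only as a bound. Compound 3, `Nc1ncnn2c([C@@H]3O[C@H](CO)[C@@H](O)[C@H]3O)cc(-c3ccc(Cl)cc3)c12`, is not yet measured and differs from compound 2 by hydrogen in place of fluoro on an aromatic carbon. From compound 2 to compound 3 no step beyond the usual scatter is expected, estimated as an at least 1.6-fold lower number from compound 2 to compound 3 (0.20 log units; that floor lies within the scatter). Compound 3 is expected near 40000 nM, with a range from 15000 nM to 100000 nM.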

Compound 3, half-maximal cytotoxic concentration: 5000 nM
For compound 3 the middle estimate is 8.0-fold (0.90 log units) above the measured one; measured number below the stated range.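

In this assay, replacing fluoro with hydrogen, from 4-chloro-3-fluorophenyl to 4-chlorophenyl, is not a silent change at this position: an at least 12-fold lower number from compound 2 to compound 3 (1.10 log units; beyond the scatter). Compound 2 gives only a limit, so this step has a floor but no known size: the limit of > 64000 nM in this assay, at which 1 of the 3 values shown sits. With the 4-chlorophenyl group held constant, the added hydroxy on the saturated ring carbon also matters: a 4.8-fold lower number from compound 1 to compound 3 (0.68 log units; beyond the scatter).

Going by these compounds, whether fluoro has the same effect on the core of compound 1 remains open. So does whether a methoxy or nitrile group at this position would behave like fluoro or hydrogen.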